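Aryl swap at the amine-bearing carbon: notes on compound 4

The compounds below may be only part of what the source reports. "The series", "measured", "known", "first", "only" and "open" are said of these compounds alone.

Measured in an assay on CHO cells for displacement of a labelled ligand from C-X-C chemokine receptor type 3 (Homo sapiens), with a stated time of 60 min; on this read-out higher numbers stand for weaker inhibition and lower numbers for stronger inhibition:
compound 1 `Cc1cc(CN(CC2CC2)[C@@H](CC(=O)O)c2ccc(Cl)cc2)ccc1OCCN1C(=O)CCC1=O`: 42 nM
compound 2 `CCN(Cc1ccc(OCCn2c(=O)ccn(C)c2=O)c(C)c1)C(CC(=O)O)c1ccc(Cl)cc1`: 428 nM
compound 3 `COc1cc(CN(CC(C)C)C(CC(=O)O)c2ccc3c(c2)CCO3)ccc1OCCN1C(=O)CCC1=O`: 41 nM

Compound 3 gives the lowest of the three numbers in this assay, but compound 1, with its chlorophenyl on the same carbon and a different amine substituent, stands within the scatter of it, so no order between these two can be read. Among the measured compounds shown here, compound 2, which also carries a chlorophenyl but a different head group and an ethyl on the nitrogen, gives the one number that lies beyond the scatter from compound 3.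

Compound 4 `COc1cc(CN(CC(C)C)C(CC(=O)O)c2ccc(Cl)c(Cl)c2)ccc1OCCN1C(=O)CCC1=O` is the next structure and differs from compound 3 by a group of 8 heavy atoms (6 carbon, 2 chlorine; one six-membered aromatic ring of carbon only) in place of a group of 9 heavy atoms (8 carbon, 1 oxygen; one five-membered non-aromatic ring with 1 hetero atom, one six-membered aromatic ring of carbon only), on a saturated chain carbon bound to an amine nitrogen and a saturated chain carbon. For the measured compounds named here, no pair of measured compounds shares this exact change, so no measured step can be carried over. What the measured values show is only that an aryl bearing chlorine on that carbon is compatible with a low number in compound 1 and with a higher number in compound 2, where the rest of the molecule also differs.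

The expectation for compound 4 is therefore a step of a 1.2-fold lower number from compound 3 to compound 4 (0.07 log units; within the scatter), not beyond the scatter in either direction. Compound 4 is estimated at 35 nM in this assay, with a range from 10 nM to 120 nM.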

Compound 4, half-maximal inhibitory concentration in the C-X-C chemokine receptor type 3 assay: 143 nM
Compound 4: the middle estimate sits 4.1-fold (0.61 log units) below what was measured, outside the stated range (above it).
By their numbers in the C-X-C chemokine receptor type 3 assay, from the lowest: compounds 3 and 1 (each within the scatter of the next); then compound 4; then compound 2.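

On a saturated chain carbon bound to an amine nitrogen and a saturated chain carbon, 3,4-dichlorophenyl in place of the group of 9 heavy atoms, with its five-membered non-aromatic ring, gives in the C-X-C chemokine receptor type 3 assay a 3.5-fold higher number from compound 3 to compound 4 (0.54 log units; beyond the scatter), the only step shown at this position with the rest of the molecule held fixed; compound 3 gives 41 nM and compound 4 gives 143 nM. The position is thus not indifferent to the aryl group it carries, although the step is modest in size. In a physicochemical assay for solubility, at pH 1.1 (a higher number here means a more soluble compound, a lower number a less soluble compound), the same change gives no change at the digits printed from compound 3 to compound 4 (within the scatter), so the exchange separates the two read-outs, moving the number in one and leaving the other unchanged at the digits printed; here compound 3 gives 3000000 nM and compound 4 gives 3000000 nM.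

No supporting data bear on why the receptor number rises with this change. Also open, going by these compounds, is whether the step follows the two chlorines or the loss of the ring oxygen, a question that plain phenyl, a pyridine ring or a methoxyphenyl on this same carbon, with the remainder of compound 3 kept, would help to settle.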